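Lengthening the Acid Chain of Compound 3

The compounds below may be only part of what the source reports. "The series", "measured", "known", "first", "only" and "open" are said of these compounds alone.

Four compounds share one core and differ in the chain it carries. In a functional assay on D4 cells (Cricetulus griseus) for inhibition, read by CellTiter-Blue, with a stated time of 96 h (on this read-out higher numbers stand for weaker inhibition and lower numbers for stronger inhibition), compound 1 (`Nc1nc2[nH]c(CCCCCCC(=O)N[C@@H](CCC(=O)O)C(=O)O)cc2c(=O)[nH]1`) gives 10.6 nM, and compound 2 (`Nc1nc2[nH]c(CCCCCCCCC(=O)N[C@@H](CCC(=O)O)C(=O)O)cc2c(=O)[nH]1`) gives 3.99 nM. Both end in an amide-linked diacid tail. Compound 3 (`Nc1nc2[nH]c(CCCCCC(=O)O)cc2c(=O)[nH]1`) ends instead in a free carboxy group.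

Compound 3 gives no number in this assay, only a limit, > 1000 nM. Its true position is therefore unknown, and it cannot be placed exactly against the other two compounds.

Compound 4 (`Nc1nc2[nH]c(CCCCCCCC(=O)O)cc2c(=O)[nH]1`) also ends in a free carboxy group but has a longer chain. The change from compound 3 is 2-carboxyethyl in place of carboxy on a saturated chain carbon, five bonds along the chain from an aromatic carbon, with 2-carboxyethyl in place of carboxy on a saturated chain carbon, five bonds along the chain from an aromatic carbon.

Among the compounds with values here, no measured pair isolates this change, so its effect must be judged indirectly. The expectation rests on compound 3, with its limit of > 1000 nM, whose free acid end compound 4 keeps. No step beyond the scatter is expected in this assay, and the assay may again report only a limit. The estimated change is a step that the limit leaves unreadable from compound 3 to compound 4. For compound 4 the expected value is 1500 nM, within an estimated range of 300 nM to 5000 nM.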

Compound 4, half-maximal inhibitory concentration: > 1000 nM
Compound 4 ended at the assay's limit; the forecaster's own chance of this, stated with the estimate: 70%; the middle value is on the limit's open side.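

Within the data shown here, no step from compound 3 to compound 4 can be read in this assay, because both compounds stop at the same limit of the assay: the limit of > 1000 nM in this assay, at which 2 of the 4 values shown sit. The compounds shown leave open how far the true values of compound 3 and compound 4 lie past that limit, and whether the longer chain changes inhibition at all.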